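Allyl to 4-chlorobenzyl ether: what to expect

A few compounds are considered here, and "the series" means these few. Any claim that something is new, unique, unknown or untested is made for them only; others in the source may bear on it.

In a functional assay on U-251 cells (Homo sapiens) for antiproliferative activity, read by MTT assay, with a stated time of 24 h (on this read-out higher numbers stand for weaker inhibition and lower numbers for stronger inhibition), compound 2 `C=CCOc1ccc2c(=O)c(-c3cc(OC)c(OC)cc3OC)coc2c1` gives 5900 nM, the highest of the two numbers shown; the nearest is compound 1 `COc1cc(OC)c(-c2coc3cc(OCC=C(C)C)ccc3c2=O)cc1OC` at 3500 nM, a step of a 1.7-fold higher number from compound 1 to compound 2 (0.23 log units; within the scatter). Compound 3 `COc1cc(OC)c(-c2coc3cc(OCC(=O)c4cccc(C(F)(F)F)c4)ccc3c2=O)cc1OC` reaches only the limit > 10000 nM in this assay. Compound 4 `COc1cc(OC)c(-c2coc3cc(OCc4ccc(Cl)cc4)ccc3c2=O)cc1OC` differs from compound 2 by 4-chlorophenyl in place of vinyl on a saturated chain carbon bound to an oxygen on an aromatic ring. The measured steps that bear on this change alter the same position: a 1.7-fold higher number from compound 1 to compound 2 (0.23 log units; within the scatter), an at least 2.8-fold higher number from compound 1 to compound 3 (0.45 log units; beyond the scatter) and an at least 1.6-fold higher number from compound 2 to compound 3 (0.22 log units; that floor lies within the scatter). Each larger group on that carbon has so far given a higher number, so a modest rise is expected, though the data are few. Compound 4 is therefore expected to give about 8000 nM (range 4000 nM to 16000 nM), a step of a 1.4-fold higher number from compound 2 to compound 4 (0.13 log units; within the scatter), with a fair chance that only a limit is reported.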

Compound 4, half-maximal inhibitory concentration: 470 nM
For compound 4 the middle estimate is 17-fold (1.23 log units) above the measured one; measured number outside the range, below it.
By their numbers in this assay, from the lowest: compound 4; then compounds 1 and 2 (each within the scatter of the next). At a limit, above all of these: compound 3.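

On the saturated chain carbon bound to an oxygen on an aromatic ring, more heavy atoms do not always mean a higher number: 4-chlorophenyl in place of vinyl gives a 13-fold lower number from compound 2 to compound 4 (1.10 log units; beyond the scatter), and in place of 2-methylprop-1-en-1-yl gives a 7.4-fold lower number from compound 1 to compound 4 (0.87 log units; beyond the scatter). Compound 4 thus goes against the earlier rise, which compounds 1, 2 and 3 alone had suggested. Against the carbonyl-linked aryl group the change gives an at least 21-fold lower number from compound 3 to compound 4 (1.32 log units; beyond the scatter), a floor only, since compound 3 stands at a limit: the limit of > 10000 nM in this assay, at which 1 of the 4 values shown sits.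

The compounds shown do not separate the contribution of the chlorine from that of the aromatic ring, on which a plain benzyl group would bear. Going by these compounds, how an amine or a carboxylic acid on that ring would read remains open.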